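Replacing the methoxyphenyl arm on the piperazine ring

This account rests on a few compounds, and the source may have more. Where it says the series, first, only, none or still open, it means among the compounds named here.

Three compounds sharing one core were tested in a functional assay on HeLa cells (Homo sapiens) for antiproliferative activity, read by CCK-8 assay, with a stated time of 72 h, tested at 8 uM; a lower number here means a weaker effect, a higher number a stronger effect of the compound at the concentration tested. Compound 1 `CN(C(=S)SCc1ccc(C(=O)Nc2ccccc2N)cc1)c1cccnc1` gives 70.5%, compound 3 `CC1CCCCN1C(=S)SCc1ccc(C(=O)Nc2ccccc2N)cc1` gives 76.3%, and compound 2 `COc1ccc(N2CCN(C(=S)SCc3ccc(C(=O)Nc4ccccc4N)cc3)CC2)cc1` gives 52.3%, the lowest of the three; its gaps to compound 1 and to compound 3 both lie beyond the scatter. For the measured compounds named here, the one measured step, a number 5.8 percentage points higher from compound 1 to compound 3 (within the scatter), changes the group on the thiocarbonyl carbon and is within the scatter. Compound 4 `Nc1ccccc1NC(=O)c1ccc(CSC(=S)N2CCN(Cc3cccnc3)CC2)cc1` differs from compound 2 elsewhere: (pyridin-3-yl)methyl in place of 4-methoxyphenyl on an amine nitrogen in a ring. Going by the values given here, no measured step touches this place, so nothing firm guides the expectation; compound 4 is expected to land near compound 2, perhaps somewhat higher, as a number 7.7 percentage points higher from compound 2 to compound 4 (within the scatter). The estimate for compound 4 is 60%, between 42% and 78%.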

Compound 4, a percentage reported as inhibition, at one concentration (the size of the read-out at that concentration, not a potency): 78%
For compound 4 the middle estimate is 18 percentage points below the measured one, within the range that was stated.
By their numbers in this assay, from the lowest: compound 2; then compounds 1, 3 and 4 (each within the scatter of the next).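

In this assay, the group on an amine nitrogen in a ring clearly matters: (pyridin-3-yl)methyl in place of 4-methoxyphenyl gives a number 25.7 percentage points higher from compound 2 to compound 4 (beyond the scatter) in this series. The earlier measured step, at the thiocarbonyl carbon, stayed within the scatter, so this is the first single change shown to move the read-out beyond it. No available evidence explains this rise.

The step changes both the aromatic ring and its link to the nitrogen, so their contributions remain unseparated. A benzyl group at this position would test the ring nitrogen alone, while a 4-methoxybenzyl group would test the added carbon link.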